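Replacing 4-Methoxyphenyl with 2-Aminophenyl on a Shared Core

The compounds below may be only part of what the source reports. "The series", "measured", "known", "first", "only" and "open" are said of these compounds alone.

Three measured compounds share one core. In an assay for binding affinity to dual specificity mitogen-activated protein kinase kinase 4 (Homo sapiens), read by KINOMEscan, tested at 100 nM (a higher number here means a weaker effect of the compound at the concentration tested, a lower number a stronger effect), compound 3 `CCCS(=O)(=O)Nc1ccc(F)c(C(=O)c2n[nH]c3ncc(-c4ccc(OC)cc4)cc23)c1F` gives 4.2%, the lowest of the three numbers, although every gap to it sits within the scatter: compound 2 `CCCS(=O)(=O)Nc1ccc(F)c(C(=O)c2n[nH]c3ncc(-c4ccccc4C)cc23)c1F` gives 7% and compound 1 `CCCS(=O)(=O)Nc1ccc(F)c(C(=O)c2n[nH]c3ncc(-c4ccccc4Cl)cc23)c1F` gives 9.3%. The steps of a number 5.1 percentage points lower from compound 1 to compound 3 (within the scatter), a number 2.8 percentage points lower from compound 2 to compound 3 (within the scatter) and a number 2.3 percentage points lower from compound 1 to compound 2 (within the scatter) all stay within the scatter. Compound 4 `CCCS(=O)(=O)Nc1ccc(F)c(C(=O)c2n[nH]c3ncc(-c4ccccc4N)cc23)c1F` differs from compound 3 by 2-aminophenyl in place of 4-methoxyphenyl on an aromatic carbon. Since every change of the aryl group so far, including a number 5.1 percentage points lower from compound 1 to compound 3 (within the scatter), moved this assay by less than the scatter, no step beyond the scatter is expected here either, so a number 1.8 percentage points higher from compound 3 to compound 4 (within the scatter) is anticipated. Compound 4 is thus estimated at 6%, in a range from 2% to 15%.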

Compound 4, a percentage reported as activity, at one concentration (the size of the read-out at that concentration, not a potency): 23%
Compound 4: middle estimate off by 17 percentage points, on the low side, outside the stated range (above it).
By their numbers in this assay, from the lowest: compounds 3, 2 and 1 (each within the scatter of the next); then compound 4.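

At this aryl position on the shared core, this assay now shows changes beyond the scatter, with a number 18.8 percentage points higher from compound 3 to compound 4 (beyond the scatter) and a number 16 percentage points higher from compound 2 to compound 4 (beyond the scatter) and a number 13.7 percentage points higher from compound 1 to compound 4 (beyond the scatter). Within the data shown here, the last two steps exchange only one group, amino in place of methyl or chloro, so this single exchange moves the number further than any step among the earlier compounds did. Nothing available here accounts for the shift. The compounds shown leave open whether a hydroxyl or a dimethylamino group in place of the amino group would raise the number as well.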